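The compounds below may be only part of what the source reports. "The series", "measured", "known", "first", "only" and "open" are said of these compounds alone.

Measured so far in a functional assay on A549 cells (Homo sapiens) for inhibition, read by MTT assay, with a stated time of 72 h; on this read-out lower numbers stand for stronger inhibition and higher numbers for weaker inhibition 
- compound 1 (`Fc1ccc(-c2nnc(SCCCN3CCN(c4nc5ccccc5o4)CC3)o2)cc1`): 75700 nM
- compound 2 (`CC(C)(C)Oc1ccc(-c2nnc(SCCCN3CCN(c4nc5ccccc5o4)CC3)o2)cc1`): 263000 nM

Compound 2 holds the higher of these two numbers, which makes it the weaker of the pair. The next compound, compound 3 (`O=C(NCc1nnc(SCCCN2CCN(c3nc4ccccc4o3)CC2)o1)c1ccccc1`), has not been measured yet. It carries benzamidomethyl in place of 4-(tert-butoxy)phenyl on an aromatic carbon.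

Going by the values given here, only one measured step bears on this change: a 3.5-fold higher number from compound 1 to compound 2 (0.54 log units; beyond the scatter), with tert-butoxy in place of fluoro on an aromatic carbon. That step is modest, yet beyond the scatter. Among the compounds with values here, no measured compound carries benzamidomethyl, so the evidence is thin. With the tert-butoxy group gone, the number may drift back toward that of compound 1 (75700 nM), and a large jump has no support in these data. In this assay the expected change is a modest one toward a lower number, estimated as a 2.4-fold lower number from compound 2 to compound 3 (0.38 log units; beyond the scatter). For compound 3 the estimated value is 110000 nM, with an expected range from 35000 nM to 320000 nM (a wide range, given a single guiding step).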

Compound 3, half-maximal inhibitory concentration: 102000 nM
Beside the measured number, compound 3's estimate is 1.1-fold (0.03 log units) above it; measured number inside the range.
By their numbers in this assay, from the lowest: compounds 1 and 3 (each within the scatter of the next); then compound 2.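

In this assay, the swap at this aromatic carbon of the five-membered aromatic ring with 2 nitrogen and 1 oxygen gives a 2.6-fold lower number from compound 2 to compound 3 (0.41 log units; beyond the scatter), so replacing 4-(tert-butoxy)phenyl with benzamidomethyl brings a modest gain in inhibition. The comparison with the fluorinated compound gives a 1.3-fold higher number from compound 1 to compound 3 (0.13 log units; within the scatter), so benzamidomethyl and 4-fluorophenyl cannot be told apart here, even though benzamidomethyl brings a hydrogen-bond donor and a double bond outside aromatic rings that 4-fluorophenyl lacks. Among these three compounds, then, only the group in compound 2 stands apart from the others, and nothing available explains why these groups give the numbers they do.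

Benzamidomethyl differs from 4-fluorophenyl in several features at once, so these compounds cannot show which of its parts, if any, affects the read-out, such as the amide hydrogen, the carbonyl or the outer benzene ring. Other groups at this carbon, such as a carboxylic acid, a simple aminomethyl or a longer chain ending in a benzene ring, would test how much variation this position accepts.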